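Chloro in Place of Carboxy on the Aryl Ring

The source may report more compounds than this note shows. Statements on the series, on what has been measured and on what is new or still open speak of the compounds shown alone.

Compound 2 `Cn1c(-c2ccc(C(=O)O)cc2)nc2c(NC3CCCC3)ncnc21` holds the highest number of the three measured compounds in an assay on CHO cells for displacement of a labelled ligand from adenosine receptor A3 (Homo sapiens), read by scintillation counting, with a stated time of 3 h (a higher number here means a weaker inhibitor, a lower number a stronger inhibitor), giving 25700 nM. Compound 1 `CCn1c(-c2ccccc2)nc2c(NC3CCCCC3)ncnc21` gives 707 nM and compound 3 `CCn1c(-c2ccccc2)nc2c(N)ncnc21` gives 5780 nM, so compound 2 stands clearly above both of them. Within the data shown here, the one step measured within this set, an 8.2-fold higher number from compound 1 to compound 3 (0.91 log units; beyond the scatter), concerns the group on the nitrogen rather than the aryl ring, and so does not bear directly on the change considered here. Compound 4 `Cn1c(-c2ccc(Cl)cc2)nc2c(NC3CCCC3)ncnc21` differs from compound 2 in a single place: chloro in place of carboxy on an aromatic carbon. Among the measured compounds shown here, no measured pair isolates that change; the closest comparison is compound 1, whose aryl ring carries no group at that position and which gives a far lower number than compound 2, though it also differs from compound 2 in two other places. The step is therefore expected to lower the number, estimated as a 29-fold lower number from compound 2 to compound 4 (1.46 log units; beyond the scatter), with wide uncertainty. Compound 4 is expected to give about 900 nM, between 200 nM and 4000 nM.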

Compound 4, inhibition constant: 1210 nM
Estimate against measurement, compound 4: 1.3-fold (0.13 log units) below; low and high end bracket the measured number.
By their numbers in this assay, from the lowest: compounds 1 and 4 (each within the scatter of the next); then compound 3; then compound 2.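

In this assay, the step at this place, para to a large group, is a 21-fold lower number from compound 2 to compound 4 (1.33 log units; beyond the scatter) and is large, so the group on the aryl ring counts for much in this series. The earlier step concerned only the group on the nitrogen, whereas this one shows what exchanging carboxy, with its 3 heavy atoms, for chloro, a single heavy atom, does on an otherwise unchanged compound. Nothing measured here accounts for the size of this step.

On these data alone, how much of the step belongs to the loss of carboxy and how much to the arrival of chloro stays open, a question that hydrogen at this place on the core of compound 2 would settle. Also open, as far as these compounds go, is how an amine, a methoxy group or a longer chain would compare here.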